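The source may report more compounds than this note shows. Statements on the series, on what has been measured and on what is new or still open speak of the compounds shown alone.

In an in vitro ADME assay on microsomes from liver (Mus musculus) for pharmacokinetics, read by LC-MS, with a stated time of 10 min, tested at 1 uM (a lower number here means slower removal, a higher number faster removal of the compound), three compounds that share a core and differ in the group on an amine nitrogen in a ring have been measured. Compound 1 `CC(C)N1C[C@H](C(=O)Nc2ccc(Cl)cc2)[C@@H](c2ccc(/C=C/C(=O)Nc3ccccc3N)cc2)C1`, with isopropyl, gives 38 mL/min/kg. Compound 2 `CC(C)(C)N1C[C@H](C(=O)Nc2ccc(Cl)cc2)[C@@H](c2ccc(/C=C/C(=O)Nc3ccccc3N)cc2)C1`, with tert-butyl, gives 20 mL/min/kg. Compound 3 `CCNC(=O)N1C[C@H](C(=O)Nc2ccc(Cl)cc2)[C@@H](c2ccc(/C=C/C(=O)Nc3ccccc3N)cc2)C1`, with ethylcarbamoyl, gives 25 mL/min/kg, which stands within the scatter of both others: the steps are a 1.5-fold lower number from compound 1 to compound 3 (0.18 log units; within the scatter) and a 1.3-fold higher number from compound 2 to compound 3 (0.10 log units; within the scatter). The remaining step, a 1.9-fold lower number from compound 1 to compound 2 (0.28 log units; within the scatter), is also within the scatter.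

Compound 4 `Nc1ccccc1NC(=O)/C=C/c1ccc([C@H]2CN(Cc3ccccc3)C[C@@H]2C(=O)Nc2ccc(Cl)cc2)cc1` is reached from compound 3 by benzyl in place of ethylcarbamoyl on an amine nitrogen in a ring, with benzyl in place of ethylcarbamoyl on an amine nitrogen in a ring. Going by the values given here, no benzyl compound has been measured, so the evidence is indirect. The three measured steps at this nitrogen set only a small scale for change, and they give no firm direction. A small rise is allowed for, since compound 1 gives 38 mL/min/kg, but compound 2 goes against it with 20 mL/min/kg. The expected step is a 1.4-fold higher number from compound 3 to compound 4 (0.15 log units; within the scatter), which would not clearly exceed the scatter. Compound 4 is estimated at 35 mL/min/kg, with an expected range from 16 mL/min/kg to 75 mL/min/kg.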

Compound 4, clearance: 81 mL/min/kg
Compound 4: the middle estimate sits 2.3-fold (0.36 log units) below what was measured, and the stated range ends below it.
By their numbers in this assay, from the lowest: compounds 2, 3 and 1 (each within the scatter of the next); then compound 4.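

Going by these compounds alone, at this ring nitrogen, this assay now shows changes that clear the scatter, which no earlier step did: benzyl in place of ethylcarbamoyl gives a 3.2-fold higher number from compound 3 to compound 4 (0.51 log units; beyond the scatter) and benzyl in place of tert-butyl gives a 4.1-fold higher number from compound 2 to compound 4 (0.61 log units; beyond the scatter) on the same nitrogen. Benzyl in place of isopropyl also clears it with a 2.1-fold higher number from compound 1 to compound 4 (0.33 log units; beyond the scatter) so compound 4 stands apart from all three earlier compounds, while those three remain within the scatter of one another. Nothing measured here explains this rise.

Compound 4 alone cannot tell whether the step belongs to the aromatic ring of benzyl or to the group as a whole. From the compounds shown here alone, how a cyclohexylmethyl or a pyridinylmethyl group on this nitrogen would compare remains open.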